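Chloro for trifluoromethyl on the benzylsulfanyl arm

A few compounds are considered here, and "the series" means these few. Any claim that something is new, unique, unknown or untested is made for them only; others in the source may bear on it.

Compound 1, `Cc1cc(-c2ccccc2)n(/C(N)=N/S(=O)(=O)c2cc(C)c(Cl)cc2SCc2cccc(C(F)(F)F)c2)n1`, in a functional assay on HeLa cells (Homo sapiens) for cytotoxicity, read by MTT assay, with a stated time of 72 h; a higher number here means a weaker inhibitor, a lower number a stronger inhibitor: 98000 nM
Compound 2, `Cc1cc(-c2ccccc2)n(/C(N)=N/S(=O)(=O)c2cc(C)c(Cl)cc2SCc2ccc(C(F)(F)F)cc2)n1`, in this assay: 19000 nM
Compound 3, `Cc1cc(S(=O)(=O)/N=C(\N)n2nccc2-c2ccccc2)c(SCc2ccc(C(F)(F)F)cc2)cc1Cl`, in this assay: 17000 nM

Compound 3 has the lowest number of the three, though its gap to compound 2 is within the scatter; only compound 1 stands clearly apart, and that separation arose in the step of a 5.2-fold lower number from compound 1 to compound 2 (0.71 log units; beyond the scatter). The step of a 1.1-fold lower number from compound 2 to compound 3 (0.05 log units; within the scatter) changed little. Compound 4, `Cc1cc(S(=O)(=O)/N=C(\N)n2nccc2-c2ccccc2)c(SCc2ccc(Cl)cc2)cc1Cl`, differs from compound 3 by chloro in place of trifluoromethyl on an aromatic carbon. Neither measured step touches this group: one moves the trifluoromethyl around the ring, the other removes a methyl elsewhere. Within the data shown here, there is thus no step that bears directly on the exchange, and no basis for expecting a shift beyond the scatter in this assay in either direction. The expected step is no change at the digits printed from compound 3 to compound 4 (within the scatter). Compound 4 is estimated at 17000 nM, with a range from 7000 nM to 45000 nM.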

Compound 4, half-maximal inhibitory concentration: 3000 nM
Beside the measured number, compound 4's estimate is 5.7-fold (0.75 log units) above it, outside the stated range (below it).
By their numbers in this assay, from the lowest: compound 4; then compounds 3 and 2 (each within the scatter of the next); then compound 1.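

Until this point the arm had been varied only in where the trifluoromethyl sits. Exchanging the group itself, with chloro in place of trifluoromethyl on the aromatic carbon para to a large group, gives a 5.7-fold lower number from compound 3 to compound 4 (0.75 log units; beyond the scatter) in this assay. That step is of similar size to a 5.2-fold lower number from compound 1 to compound 2 (0.71 log units; beyond the scatter), so among these compounds the identity of this group counts for about as much as its placement, and nothing available here accounts for the step.

On these data alone, it remains open whether the lower number is particular to chloro or also extends to other groups at this place, such as fluoro, bromo, methoxy or an amine. As far as these compounds go, it is also open whether the same exchange gives a step of this size when the methyl of compound 2 is present on the core.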